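Adenine-derived spleen activators: effect of removing the butyl chain

The compounds below may be only part of what the source reports. "The series", "measured", "known", "first", "only" and "open" are said of these compounds alone.

Measured compounds:
- compound 1, `Cc1ccc(Cn2c(O)nc3c(N)ncnc32)cc1`: 10 uM
- compound 2, `Nc1nc(SCc2ccccc2)nc2c1nc(O)n2Cc1ccccc1`: 0.1 uM
- compound 3, `CCCCNc1nc(N)c2nc(O)n(Cc3ccccc3)c2n1`: 1 uM

All three were tested in a functional assay (spleen, spleen) for activation, with Mus musculus as the target; a lower number here means that less compound is needed, a higher number that more compound is needed for the effect. Compound 3 stands second of the three numbers: compound 1 gives 10 uM, a higher number, and compound 2 gives 0.1 uM, the lowest of the set. Both gaps lie beyond the scatter.

The next compound is compound 4, `Nc1nc(N)c2nc(O)n(Cc3ccccc3)c2n1`, not yet measured in this assay. It differs from compound 3 by hydrogen in place of butyl on a nitrogen on an aromatic ring.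

Among the compounds with values here, only one measured step touches the same aromatic carbon: a 10-fold higher number from compound 2 to compound 3 (1.00 log units; beyond the scatter). That step exchanged one group for another, so it does not show directly what a bare amino gives; it does show that this position moves the number by a modest amount. Removing the butyl chain leaves a smaller group at that carbon than either compound 2 or compound 3 carries. The expected step is therefore an increase in this assay, of about the size seen between compound 2 and compound 3, but the direction is inferred from a single step and stays uncertain.

For compound 4 the number in this assay is estimated at 5 uM, with a range of 1 uM to 30 uM, a step of a 5.0-fold higher number from compound 3 to compound 4 (0.70 log units; beyond the scatter) from compound 3 being expected.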

Compound 4, minimum effective concentration: 10 uM
The estimate for compound 4 lay 2.0-fold (0.30 log units) below the measured number; measured number inside the range.
By their numbers in this assay, from the lowest: compound 2; then compound 3; then compounds 1 and 4 (each within the scatter of the next).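

In this assay, within the data shown here, taking the butyl chain off the nitrogen gives a 10-fold higher number from compound 3 to compound 4 (1.00 log units; beyond the scatter), the first direct reading of what this chain contributes to the number, as the earlier step exchanged one whole group for another. Together with a 100-fold higher number from compound 2 to compound 4 (2.00 log units; beyond the scatter), this puts the groups on this aromatic carbon in an order from the lowest number to the highest: benzylsulfanyl, butylamino, amino, with each gap beyond the scatter and a large span overall for a change at one place. No measurement accompanies these numbers that could explain the order, which therefore stands as a description of three compounds only.

Going by these compounds, whether the low number of compound 2 belongs to the sulfur link or to the benzyl group stays open; a benzylamino or a butylsulfanyl group on this carbon would separate the two. Also open, on these data alone, is how the number responds to a chain on the nitrogen other than butyl, such as a shorter ethyl, a longer hexyl or a branched isopropyl.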